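A few compounds are considered here, and "the series" means these few. Any claim that something is new, unique, unknown or untested is made for them only; others in the source may bear on it.

Measured in a functional assay on CCRF-CEM cells (Homo sapiens), read by MTT assay, with a stated time of 72 h; on this read-out lower numbers stand for stronger inhibition and higher numbers for weaker inhibition:
- compound 1 `C#Cc1cn([C@@H]2O[C@H](CO)[C@@H](O)[C@H]2O)c2ncnc(OC)c12`: > 20000 nM, a limit
- compound 2 `C#Cc1cn([C@@H]2O[C@H](CO)[C@@H](O)[C@H]2O)c2ncnc(SC)c12`: > 20000 nM, a limit
- compound 3 `Cc1ncnc2c1c(-c1ccsc1)cn2[C@@H]1O[C@H](CO)[C@@H](O)[C@H]1O`: 11200 nM

Among the compounds with values here, compound 3 gives 11200 nM, the only actual number. The other two results stand at the limit of > 20000 nM in this assay, at which 2 of the 3 values shown sit, so they fix no distance from compound 3.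

The compound still to be measured is compound 4 `C#Cc1cn([C@@H]2O[C@H](CO)[C@@H](O)[C@H]2O)c2ncnc(C)c12`. It differs from compound 3 in one place: ethynyl in place of thiophen-3-yl on an aromatic carbon. Ethynyl takes the place of thiophen-3-yl on an aromatic carbon of the five-membered aromatic ring.

Within the data shown here, only one measured step exists, and it helps little. It is a step that the two limits leave unreadable from compound 1 to compound 2, and it concerns a different place on the molecule, so it gives no size to carry over. The more useful hint is indirect. Compound 4 shares its ethynyl with compound 1, whose > 20000 nM is a limit. Compound 2 also carries ethynyl, and its > 20000 nM is a limit too. Among the measured compounds shown here, no measured step isolates the exchange of thiophen-3-yl for ethynyl.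

The step of a 1.1-fold lower number from compound 3 to compound 4 (0.05 log units; within the scatter) is therefore expected to stay within the scatter in this assay, with a weaker result or a mere limit remaining quite possible. For compound 4 the estimated value is 10000 nM, with an expected range from 2000 nM to 20000 nM.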

Compound 4, half-maximal inhibitory concentration: 5600 nM
Beside the measured number, compound 4's estimate is 1.8-fold (0.25 log units) above it; the range from low to high includes it.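

In this assay, ethynyl in place of thiophen-3-yl on this aromatic carbon of the five-membered ring gives a 2.0-fold lower number from compound 3 to compound 4 (0.30 log units; within the scatter), so a group with no ring and a ring-bearing group cannot be told apart here. Within the data shown here, compound 4 is also the first compound with ethynyl at this position to give an actual number, and with ethynyl held constant the group on the other aromatic carbon separates the results: methyl in place of methylsulfanyl gives an at least 3.5-fold lower number from compound 2 to compound 4 (0.55 log units; beyond the scatter), and methyl in place of methoxy gives an at least 3.5-fold lower number from compound 1 to compound 4 (0.55 log units; beyond the scatter). Both sizes are minimum sizes and the step between compound 1 and compound 2 cannot be read, as those two compounds give only a limit: the limit of > 20000 nM in this assay, at which 2 of the 4 values shown sit.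

The compounds shown leave open whether a longer chain ending in a triple bond, or an amine, on the ethynyl-bearing carbon would give a result beyond the scatter from compound 4. They also leave open whether thiophen-3-yl and ethynyl would remain indistinguishable with methoxy or methylsulfanyl in place of the methyl.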